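This account rests on a few compounds, and the source may have more. Where it says the series, first, only, none or still open, it means among the compounds named here.

Compound 1 `Cc1nc(C(=O)Nc2ccc(Cl)c(-c3nnc4c(Cl)cccn34)c2)cs1`: in a functional assay on MCF7 cells (Homo sapiens) for antiproliferative activity, read by MTT assay, with a stated time of 72 h (a lower number here means a stronger inhibitor, a higher number a weaker inhibitor), compound 1 gives > 100000 nM, and this is a limit of the assay rather than a number.
Compound 2 `O=C(Nc1ccc(Cl)c(-c2nnc3c(Cl)cccn23)c1)c1cccc(Cl)c1`: in this assay compound 2 gives 71900 nM.
Compound 3 `CS(=O)(=O)c1ccc(C(=O)Nc2ccc(Cl)c(-c3nnc4c(Cl)cccn34)c2)cc1`: in this assay compound 3 gives 94200 nM.

All three compounds share one core and differ only in the group attached to the carbonyl carbon of the amide. Compound 3 has the highest of the two numbers shown, but its nearest neighbour is compound 2, and that gap a 1.3-fold higher number from compound 2 to compound 3 (0.12 log units; within the scatter) lies within the scatter. Against compound 1 only a limit is available, so an at least 1.0-fold lower number from compound 1 to compound 3 (0.02 log units; that floor lies within the scatter) and an at least 1.3-fold lower number from compound 1 to compound 2 (0.14 log units; that floor lies within the scatter) say no more than that the two phenyl amides gave numbers where the thiazole amide gave none. Compound 4 `O=C(Nc1ccc(Cl)c(-c2nnc3c(Cl)cccn23)c1)c1ccc(Cl)cc1Cl` carries a third group on that carbonyl carbon: 2,4-dichlorophenyl in place of 4-(methylsulfonyl)phenyl on a carbonyl carbon.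

Among the compounds with values here, the one step that bears directly on this change is the swap of one phenyl group for another, a 1.3-fold higher number from compound 2 to compound 3 (0.12 log units; within the scatter), which stayed within the scatter. Within the data shown here, nothing among the measured compounds therefore points to a step beyond the scatter, in either direction, for compound 4 in this assay. The expected step is a 1.4-fold lower number from compound 3 to compound 4 (0.16 log units; within the scatter). Compound 4 is estimated at 65000 nM, with a range from 25000 nM to 170000 nM.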

Compound 4, half-maximal inhibitory concentration: 78200 nM
Compound 4: the middle estimate sits 1.2-fold (0.08 log units) below what was measured; the range from low to high includes it.
By their numbers in this assay, from the lowest: compounds 2, 4 and 3 (each within the scatter of the next). At a limit, above all of these: compound 1.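

Replacing 4-(methylsulfonyl)phenyl with 2,4-dichlorophenyl on the carbonyl carbon removes both of the hydrogen-bond acceptors counted on the leaving group and brings in chlorine, yet in this assay the result is a 1.2-fold lower number from compound 3 to compound 4 (0.08 log units; within the scatter). The change from the 3-chlorophenyl group gives a 1.1-fold higher number from compound 2 to compound 4 (0.04 log units; within the scatter), so these three phenyl amides, carrying quite different groups on the ring, cannot be told apart at this position in this test. Compound 1 remains a limit and not a number, so only a floor can be read, an at least 1.2-fold lower number from compound 1 to compound 4 (0.10 log units; that floor lies within the scatter), and the thiazole amide cannot be placed relative to the phenyl amides: the limit of > 100000 nM in this assay, at which 1 of the 4 values shown sits.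

The compounds shown leave open whether any group on this carbonyl carbon can give a step beyond the scatter, for example a phenyl ring carrying an amine or a carboxylic acid, or a longer alkyl chain in place of the ring. They also leave open whether the numbers would move with a change elsewhere on the shared core, since all four compounds keep it unchanged.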